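The source may report more compounds than this note shows. Statements on the series, on what has been measured and on what is new or still open speak of the compounds shown alone.

Series notes. The set comprises compound 1 `C#CCSc1nnc(C)n1N1C(=O)c2ccccc2C1=O`, compound 2 `CCCc1nnc(SCc2ccccc2Cl)n1N1C(=O)c2ccccc2C1=O`, compound 3 `C=CCSc1nnc(-c2cc(OC)c(OC)c(OC)c2)n1N1C(=O)c2ccccc2C1=O` and the as yet unmeasured compound 4 `COc1cc(-c2nnc(SCC(=O)c3ccc(C)cc3)n2N2C(=O)c3ccccc3C2=O)cc(OC)c1OC`. Every result so far comes from a functional assay on HepG2 cells (Homo sapiens) for cytotoxicity, read by MTT assay, with a stated time of 48 h; on this read-out lower numbers stand for stronger inhibition and higher numbers for weaker inhibition. In this assay compound 1 returns only a limit, > 200000 nM. Compound 2 likewise gives a limit, > 200000 nM. Compound 3 also stops at a limit, > 200000 nM. Where compound 3 stands can thus only be stated against the limit of > 200000 nM in this assay, at which 3 of the 3 values shown sit: no number separates it from compound 1 or compound 2, and no step between any two measured compounds can be sized.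

Compound 4 differs from compound 3 by a single change, ((4-methylphenyl)carbonyl in place of vinyl on a saturated chain carbon bound to a sulfur), so that allylsulfanyl becomes (((4-methylphenyl)carbonyl)methyl)sulfanyl on the shared core. For the measured compounds named here, with nothing but limits in hand, no measured step can guide the direction or size of this change. The expectation for the step from compound 3 to compound 4 is none beyond the scatter, an at least 1.3-fold lower number from compound 3 to compound 4 (0.12 log units; that floor lies within the scatter), with the caveat that compound 3 itself is only bounded. Compound 4 is expected to give about 150000 nM, within 40000 nM to 500000 nM, and most likely to be reported again as a limit rather than a number.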

Compound 4, half-maximal inhibitory concentration: 9440 nM
Beside the measured number, compound 4's estimate is 16-fold (1.20 log units) above it, and the stated range ends above it.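

In this assay, the sulfur substituent gives the first separation in the series, with an at least 21-fold lower number from compound 3 to compound 4 (1.32 log units; beyond the scatter). This shows that a single change at this place, on a saturated chain carbon bound to a sulfur, can bring the shared core from a limit to a measurable number, which compounds 1, 2 and 3 could not show. Because compound 3 returns only a limit, the step is a floor and not a measured size: the limit of > 200000 nM in this assay, at which 3 of the 4 values shown sit.

Going by these compounds, the change from allylsulfanyl to (((4-methylphenyl)carbonyl)methyl)sulfanyl brings in a carbonyl, an aromatic ring and a methyl group together, so it remains open which of these parts carries the step; a benzyl group or an unsubstituted phenylcarbonylmethyl group on the same sulfur would begin to separate them. On these data alone, it also remains open whether the same sulfur substituent has a comparable effect on the core of compound 1, since compound 4 differs from that compound in more than one place.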